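Working notes: from compound 2 to compound 4

The compounds below may be only part of what the source reports. "The series", "measured", "known", "first", "only" and "open" are said of these compounds alone.

In a functional assay on MDA-MB-231 cells (Homo sapiens) for antiproliferative activity, read by MTT assay, with a stated time of 72 h (a higher number here means a weaker inhibitor, a lower number a stronger inhibitor), three compounds of the series have been measured. Compound 2 `O=C(CCc1cccc2c1B(O)OC2)Nc1cccc(-c2ccccc2)c1` gives 220 nM, the lower of the two actual numbers. Compound 3 `O=C(CCc1cccc2c1B(O)OC2)Nc1cccc(-c2ccc(OC(F)(F)F)cc2)c1` gives 640 nM and is the nearest neighbour of compound 2. Compound 1 `CCOC(=O)c1ccc(NC(=O)CCc2cccc3c2B(O)OC3)cc1` gives > 100000 nM, which is a limit of the assay and not a number.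

Compound 4 `CSc1cccc(-c2cccc(NC(=O)CCc3cccc4c3B(O)OC4)c2)c1` is still unmeasured. Its structure departs from compound 2 by methylsulfanyl in place of hydrogen on an aromatic carbon, with methylsulfanyl in place of hydrogen on an aromatic carbon, so that phenyl becomes 3-(methylsulfanyl)phenyl.

For the measured compounds named here, one measured step bears on this change: a 2.9-fold higher number from compound 2 to compound 3 (0.46 log units; beyond the scatter), with trifluoromethoxy in place of hydrogen on an aromatic carbon. That step is modest, and it is a single example with a different group, so it offers only a weak guide. Going by the values given here, on the evidence of a 2.9-fold higher number from compound 2 to compound 3 (0.46 log units; beyond the scatter) alone, a modest rise in the number in this assay is expected, probably no larger than that step. The expected step is a 1.8-fold higher number from compound 2 to compound 4 (0.26 log units; within the scatter). For compound 4 the estimated value is 400 nM. The expected range for compound 4 runs from 130 nM to 1300 nM.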

Compound 4, half-maximal inhibitory concentration: 150 nM
The estimate for compound 4 lay 2.7-fold (0.43 log units) above the measured number; the range from low to high includes it.
By their numbers in this assay, from the lowest: compounds 4 and 2 (each within the scatter of the next); then compound 3. At a limit, above all of these: compound 1.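

In this assay, for the compounds shown here, the step of a 1.5-fold lower number from compound 2 to compound 4 (0.17 log units; within the scatter) is the first evidence that a group at this place, meta to a large group on the outer ring, can leave the number level with that of the unsubstituted phenyl. Substitution on this ring therefore does not by itself carry the cost seen in a 2.9-fold higher number from compound 2 to compound 3 (0.46 log units; beyond the scatter), since 3-(methylsulfanyl)phenyl in compound 4 and phenyl in compound 2 cannot be told apart here, although that comparison rests on one example of each kind and the two substituents differ in both identity and place on the ring. Nothing among the data shown gives a cause for the step from hydrogen to methylsulfanyl.

The compounds shown leave open whether the sulfur atom matters, which methoxy at the same aromatic carbon would test, and whether a longer chain such as ethylsulfanyl would hold the number as well. They also leave open how an amine or a carboxylic acid would read at this place, and whether trifluoromethoxy there would give the step seen for compound 3.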